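The source may hold more compounds than are shown below. What is called first, only, known or untested is meant among the compounds shown, and "the series" means these compounds.

Compound 1 `NC(=O)c1cc(Br)ccc1NC(=O)/C=C/c1ccccc1`: 917 nM
Compound 2 `NC(=O)c1cc(I)ccc1NC(=O)/C=C/c1ccccc1`: 343 nM

In a functional assay on COLO 205 cells (Homo sapiens) for inhibition, read by sulforhodamine B assay, with a stated time of 48 h (a lower number here means a stronger inhibitor of growth, a higher number a weaker inhibitor of growth), compound 2 gives 343 nM, the lower of the two numbers, and so it is the stronger inhibitor of growth so far. Compound 3 `NC(=O)c1cc(I)ccc1NC(=O)/C=C/c1ccccc1Cl` is made from it by one change, chloro in place of hydrogen on an aromatic carbon, which turns phenyl into 2-chlorophenyl. For the measured compounds named here, only one measured step exists, a 2.7-fold lower number from compound 1 to compound 2 (0.43 log units; beyond the scatter), a modest one, and it is iodo in place of bromo at another place. It therefore says nothing direct about adding chloro, and the data give no direction for this change. The expected change is small, a 1.1-fold lower number from compound 2 to compound 3 (0.06 log units; within the scatter), with no shift beyond the scatter anticipated. For compound 3 the estimated value in this assay is 300 nM, with an expected range of 90 nM to 1000 nM.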

Compound 3, concentration for 50% growth inhibition: 797 nM
Compound 3: middle estimate off by 2.7-fold (0.42 log units), on the low side; the measured number falls inside the stated range.
By their numbers in this assay, from the lowest: compound 2; then compounds 3 and 1 (each within the scatter of the next).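

In this assay, chloro in place of hydrogen, which turns phenyl into 2-chlorophenyl, gives a 2.3-fold higher number from compound 2 to compound 3 (0.37 log units; beyond the scatter), so this single added atom modestly weakens growth inhibition. For the compounds shown here, this is the first reading at this end of the molecule, as the earlier step concerned only iodo in place of bromo at another place; it shows that a carbon ortho to a large group on this ring does not take chloro without some loss, at least with iodo present. Nothing available explains this loss. On these data alone, it remains open whether a methyl or methoxy group at this place would give a similar result, or whether chloro on another carbon of the ring would. Also open, as far as these compounds go, is whether the same change would have a similar effect with bromo in place of iodo.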